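From 4-Chlorophenyl to Methoxy on a Carbonyl

A few compounds are considered here, and "the series" means these few. Any claim that something is new, unique, unknown or untested is made for them only; others in the source may bear on it.

For the measured compounds named here, in a functional assay on MT4 cells (Homo sapiens) for cytotoxicity (a higher number here means that more compound is tolerated, a lower number that less compound is tolerated), compound 3 `CCc1c(O)nc(SCC(=O)c2ccc(Cl)cc2)nc1Cc1cccc2ccccc12` gives 56000 nM, the higher of the two exact numbers so far. Compound 2 `CCc1c(O)nc(SCC(=O)c2ccc(C)cc2)nc1Cc1cccc2ccccc12` gives 6000 nM. Chloro in place of methyl on an aromatic carbon makes up the only measured step, a 9.3-fold higher number from compound 2 to compound 3 (0.97 log units; beyond the scatter). The next structure, compound 4 `CCc1c(O)nc(SCC(=O)OC)nc1Cc1cccc2ccccc12`, has methoxy in place of 4-chlorophenyl on a carbonyl carbon. Going by the values given here, the measured step involves a different change, so it shows only that one small swap can move this number noticeably. Compound 1 `COC(=O)CSc1nc(O)c(C)c(Cc2cccc3ccccc23)n1`, which also carries the (methoxycarbonyl)methyl group, stands at >= 296000 nM, a limit of the assay, and this points upward for compound 4. The expected change is modest: a 2.7-fold higher number from compound 3 to compound 4 (0.43 log units; beyond the scatter). Compound 4 is estimated at 150000 nM, within an expected range of 50000 nM to 300000 nM.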

Compound 4, half-maximal cytotoxic concentration: >= 196000 nM
Compound 4 was reported as a limit; the forecaster's own chance of this, stated with the estimate: 45%; middle value at least 1.3-fold (0.11 log units) from the limit.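

In this assay, methoxy in place of 4-chlorophenyl on the carbonyl carbon gives an at least 3.5-fold higher number from compound 3 to compound 4 (0.54 log units; beyond the scatter), and methoxy in place of 4-methylphenyl gives an at least 32-fold higher number from compound 2 to compound 4 (1.51 log units; beyond the scatter). So at this position, the earlier chloro-for-methyl swap is not the only change that raises the number: losing the aromatic ring altogether raises it from both aryl compounds. Compound 4 is reported only as a limit: the limit of >= 196000 nM in this assay, at which 1 of the 4 values shown sits.

The step between compound 1 and compound 4, both limits, cannot be read. As far as these compounds go, whether an amide or a carboxylic acid at this carbonyl carbon would keep the number as high remains open.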